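The source may report more compounds than this note shows. Statements on the series, on what has been measured and on what is new or still open speak of the compounds shown alone.

Measured so far:
Compound 1 `O=C(O)/C(S)=C/c1ccccc1Cl` gives 11900 nM in an assay on isolated protein for inhibition of Calpain-1 catalytic subunit (Sus scrofa), read by FRET; on this read-out higher numbers stand for weaker inhibition and lower numbers for stronger inhibition.
Compound 2 `O=C(O)/C(S)=C/c1c[nH]c2ccc(Br)cc12` gives 6 nM in this assay.

Of these two numbers, compound 1 stands highest. Compound 2 shows a far lower value, and the gap between the two readings lies well beyond the usual scatter; since the two compounds differ in more than one place, their values can only be set side by side as they stand. Compound 3 `O=C(O)/C(S)=C/c1ccccc1Br` has not yet been measured. It differs from compound 1 by bromo in place of chloro on an aromatic carbon. Within the data shown here, no step between measured compounds that differ in a single place has been recorded, so there is no measured precedent for this exchange. For compound 3 the step of a 1.3-fold lower number from compound 1 to compound 3 (0.12 log units; within the scatter) is expected to stay within the scatter, with a slightly lower number if anything. Compound 3 is estimated at 9000 nM in this assay, with a range from 4000 nM to 25000 nM.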

Compound 3, half-maximal inhibitory concentration: 21000 nM
Compound 3: the middle estimate sits 2.3-fold (0.37 log units) below what was measured, and the stated range covers the measured number.
By their numbers in this assay, from the lowest: compound 2; then compounds 1 and 3 (each within the scatter of the next).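

In this assay, among these compounds, bromo in place of chloro on an aromatic carbon gives a 1.8-fold higher number from compound 1 to compound 3 (0.25 log units; within the scatter) and so provides the only single-place step in this set. At this place, ortho to a group of 6 heavy atoms, the two halogens cannot be told apart, and compounds 1 and 3 read as equivalent within the usual scatter. No accompanying measurement offers an explanation for this result.

Still open, from the compounds shown here alone, is whether the same place would accept something other than a halogen of this kind, such as a methoxy group, a trifluoromethyl group, an amine or a plain hydrogen. Also open, going by these compounds, is whether the exchange of chloro for bromo would read the same way at another carbon of the six-membered aromatic ring.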